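A few compounds are considered here, and "the series" means these few. Any claim that something is new, unique, unknown or untested is made for them only; others in the source may bear on it.

Compound 1 `COc1cc(Cl)cc(-c2nn(-c3cccc(NC(=O)Nc4cc(C(F)(F)F)cc(C(F)(F)F)c4)c3)cc2-c2ccncc2)c1`: -34%
Compound 2 `COc1cc(Cl)cc(-c2nn(-c3cccc(NC(=O)Nc4ccc(Cl)c(Cl)c4)c3)cc2-c2ccncc2)c1`: -7%

In a functional assay on MOLT-4 cells (Homo sapiens) for inhibition, read by sulforhodamine B assay, with a stated time of 48 h, tested at 100 uM (a lower number here means a stronger effect, a higher number a weaker effect of the compound at the concentration tested), compound 2 gives -7%, the higher of the two numbers, and compound 1 gives -34%, a gap beyond the scatter. Compound 3 `COc1cc(Cl)cc(-c2nn(-c3cccc(NC(=O)Nc4cccc(C(F)(F)F)c4)c3)cc2-c2ccncc2)c1` has not been measured. It differs from compound 2 in one place: 3-(trifluoromethyl)phenyl in place of 3,4-dichlorophenyl on an amide-type nitrogen. Within the data shown here, no step between measured compounds covers this kind of change, so the expectation rests only on compound 1 at -34% and compound 2. A modest move toward a stronger effect is expected, a number 8 percentage points lower from compound 2 to compound 3 (within the scatter), close to the edge of the scatter. Compound 3 is expected to give -15%, estimated between -40% and 10%.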

Compound 3, a percentage reported as activity, at one concentration (the size of the read-out at that concentration, not a potency): -36%
The estimate for compound 3 lay 21 percentage points above the measured number; measured number inside the range.
By their numbers in this assay, from the lowest: compounds 3 and 1 (each within the scatter of the next); then compound 2.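

On the amide-type nitrogen, 3-(trifluoromethyl)phenyl in place of 3,4-dichlorophenyl gives a number 29 percentage points lower from compound 2 to compound 3 (beyond the scatter), so the effect in this assay depends on what this aromatic ring carries. Hydrogen in place of one trifluoromethyl gives a number 2 percentage points lower from compound 1 to compound 3 (within the scatter), so the second trifluoromethyl group adds nothing that can be told from the scatter. Nothing available explains either result. Still open, on these data alone, is whether a phenyl ring with a single chlorine would give the stronger effect. A methoxy group or a carboxylic acid in place of the trifluoromethyl is also untested among the compounds shown.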